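Catechol replacement on the arylidene of compound 1

The compounds below may be only part of what the source reports. "The series", "measured", "known", "first", "only" and "open" are said of these compounds alone.

Measured compounds in a functional assay on HepG2 cells (Homo sapiens) for cytotoxicity, read by MTT assay, with a stated time of 48 h; a higher number here means a weaker inhibitor, a lower number a stronger inhibitor:
- compound 1, `Cc1ccc(/C=C2/S/C(=N/c3ccccc3)N(Cc3ccncc3)C2=O)cc1`: 19700 nM
- compound 2, `O=C1/C(=C\c2ccc([N+](=O)[O-])cc2)S/C(=N/c2ccccc2)N1Cc1ccncc1`: 18900 nM
- compound 3, `CN(C)c1ccc(/C=C2/S/C(=N/c3ccccc3)N(Cc3ccncc3)C2=O)cc1`: 52600 nM

Compound 1 stands second highest of the three numbers. Its nearest neighbour is compound 2, with a 1.0-fold lower number from compound 1 to compound 2 (0.02 log units; within the scatter); its furthest is compound 3, with a 2.7-fold higher number from compound 1 to compound 3 (0.43 log units; beyond the scatter). Compound 2 and compound 3 differ by a 2.8-fold higher number from compound 2 to compound 3 (0.44 log units; beyond the scatter).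

Compound 4, `O=C1/C(=C\c2ccc(O)c(O)c2)S/C(=N/c2ccccc2)N1Cc1ccncc1`, has not yet been measured in this assay. It departs from compound 1 by 3,4-dihydroxyphenyl in place of 4-methylphenyl on a double-bonded chain carbon bound to a double-bonded ring carbon.

The three measured steps all exchange the group on the same aromatic ring, so each bears on this step. One of them, nitro for methyl, left the number within the scatter; the two that introduce dimethylamino raised the number modestly. Within the data shown here, none of them introduces a hydroxyl, so the direction for 3,4-dihydroxyphenyl has no direct precedent here. Given that the measured exchanges moved the number by at most a modest amount, a step of similar size or none beyond the scatter is expected, with the direction uncertain.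

Compound 4 is therefore expected to give about 20000 nM, within 8000 nM to 55000 nM, that is an estimated 1.0-fold higher number from compound 1 to compound 4 (0.01 log units; within the scatter).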

Compound 4, half-maximal inhibitory concentration: 16200 nM
Beside the measured number, compound 4's estimate is 1.2-fold (0.09 log units) above it, and the stated range covers the measured number.
By their numbers in this assay, from the lowest: compounds 4, 2 and 1 (each within the scatter of the next); then compound 3.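

In this assay, 3,4-dihydroxyphenyl is the only group shown with hydrogen-bond donors on a double-bonded chain carbon bound to a double-bonded ring carbon, yet compound 4 stays within the scatter of the 4-methylphenyl and 4-nitrophenyl compounds (a 1.2-fold lower number from compound 1 to compound 4 (0.08 log units; within the scatter); a 1.2-fold lower number from compound 2 to compound 4 (0.07 log units; within the scatter)). This widens the set of groups that give indistinguishable numbers here: 2 hydrogen-bond donors and 2 hydrogen-bond acceptors enter in the step from compound 1 without a change beyond the scatter, so their presence alone does not separate compound 4 from compound 1 in this assay. Compound 3, with 4-(dimethylamino)phenyl, remains the one compound set apart from the other three, and the new comparison gives the largest of the steps at this position (a 3.2-fold lower number from compound 3 to compound 4 (0.51 log units; beyond the scatter)), though no measurement shown explains why the dimethylamino compound differs.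

From the compounds shown here alone, whether a single hydroxyl, a methoxy group, a carboxylic acid or a primary amine on the same aromatic ring would also stay within the scatter remains open, as does the separate contribution of each hydroxyl in 3,4-dihydroxyphenyl. The compounds shown also leave open how a longer chain at this place would behave, and whether other parts of the shared core offer a larger change in the number than this position has given.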